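Cytotoxicity of a Pyrazinone Nucleoside Series on Vero Cells

The source may report more compounds than this note shows. Statements on the series, on what has been measured and on what is new or still open speak of the compounds shown alone.

Compound 1 `O=c1[nH]c(=O)n(C2C[C@@H](O)[C@@H](CO)O2)nc1/C=C(\F)Br` gives > 500 ug/mL in a functional assay on Vero cells (Chlorocebus sabaeus) for cytotoxicity (a lower number here means a stronger inhibitor, a higher number a weaker inhibitor), which is a limit of the assay.
Compound 2 `CS/C=C/c1nn(C2C[C@@H](O)[C@@H](CO)O2)c(=O)[nH]c1=O` gives 420 ug/mL in this assay.
Compound 3 `O=c1[nH]c(=O)n(C2C[C@@H](O)[C@@H](CO)O2)nc1C=C(Br)Br` gives > 500 ug/mL in this assay, again a limit of the assay.

Compound 3 stands at the upper edge of what this assay reports: its value is a limit, not a number, and it shares that position with compound 1 (the limit of > 500 ug/mL in this assay, at which 2 of the 3 values shown sit). The step of an at least 1.1-fold higher number from compound 2 to compound 3 (0.07 log units; that floor lies within the scatter) lies within the scatter, and the step that the two limits leave unreadable from compound 1 to compound 3 cannot be read from the two limits.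

Compound 4 `O=Cc1nn(C2C[C@@H](O)[C@@H](CO)O2)c(=O)[nH]c1=O` differs from compound 3 by formyl in place of 2,2-dibromoethenyl on an aromatic carbon. Neither of the readable steps at this aromatic carbon, an at least 1.1-fold lower number from compound 1 to compound 2 (0.07 log units; that floor lies within the scatter) and an at least 1.1-fold higher number from compound 2 to compound 3 (0.07 log units; that floor lies within the scatter), has moved the value beyond the scatter, so no step beyond the scatter is expected for the change to compound 4 in this assay. Compound 4 is therefore expected to give 450 ug/mL, within a range of 150 ug/mL to 1000 ug/mL, and the expected step is an at least 1.1-fold lower number from compound 3 to compound 4 (0.04 log units; that floor lies within the scatter).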

Compound 4, concentration for 50% inhibition: 180 ug/mL
The estimate for compound 4 lay 2.5-fold (0.40 log units) above the measured number; the range from low to high includes it.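

Formyl is the only group shown at this aromatic carbon that moves the value in this assay beyond the scatter, with an at least 2.7-fold lower number from compound 3 to compound 4 (0.44 log units; beyond the scatter), with a 2.3-fold lower number from compound 2 to compound 4 (0.37 log units; beyond the scatter) and with an at least 2.7-fold lower number from compound 1 to compound 4 (0.44 log units; beyond the scatter). The position therefore does respond to change in this assay, and the change from 2,2-dibromoethenyl to formyl brings a shorter group with a hydrogen-bond acceptor in place of a longer one without, though these two differences travel together here. The steps from compound 1 and compound 3 are only floors, since each of those compounds sits at a limit of the assay: the limit of > 500 ug/mL in this assay, at which 2 of the 4 values shown sit.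

The compounds shown do not separate the carbonyl from the shorter length. A hydroxymethyl group, a carboxylic acid or an amine at this aromatic carbon would be needed to tell how far the lower number extends.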